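Ethoxy for cyclopropyl on a tightly bound compound

The source may report more compounds than this note shows. Statements on the series, on what has been measured and on what is new or still open speak of the compounds shown alone.

In an ADME assay on a cell-free system (plasma, Homo sapiens) for protein binding, compound 1 (`Cc1cc(Nc2ccc(S(F)(F)(F)(F)F)cc2)n2nc(C3CC3)nc2n1`) gives 97.7%, the lowest unbound fraction of the three measured compounds. Compound 2 (`Cc1cc(Nc2ccc(C(F)(F)F)cc2)n2nc(C3CC3)nc2n1`) gives 92.8%, and compound 3 (`COCCc1nc2nc(C)cc(Nc3ccc(C(F)(F)F)cc3)n2n1`) gives 73.7%. Compound 4 (`CCOc1nc2nc(C)cc(Nc3ccc(S(F)(F)(F)(F)F)cc3)n2n1`) is still unmeasured and differs from compound 1 in one place: ethoxy in place of cyclopropyl on an aromatic carbon. In words, this is ethoxy in place of cyclopropyl on an aromatic carbon.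

The closest measured change is a 3.7-fold higher unbound fraction from compound 2 to compound 3 (0.56 log units; beyond the scatter), with 2-methoxyethyl in place of cyclopropyl on an aromatic carbon. The other measured change, a 3.1-fold higher unbound fraction from compound 1 to compound 2 (0.50 log units; beyond the scatter), concerns a different place, and compound 4 keeps the group of compound 1 there, so it bears on this change only loosely. Ethoxy itself has no measurement among these compounds, so a step in the same direction but somewhat smaller is assumed. The expected size in this assay is a 2.2-fold higher unbound fraction from compound 1 to compound 4 (0.34 log units; beyond the scatter). For compound 4 the estimate is 95%, with an expected range from 90% to 97.5%.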

Compound 4, plasma protein binding: 97.7%
Compound 4: the middle estimate sits 2.2-fold (0.34 log units) (unbound fraction) above what was measured; the measured number lies above the stated range.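

In this assay, ethoxy in place of cyclopropyl on this aromatic carbon gives no change at the digits printed from compound 1 to compound 4 (within the scatter), so on the core of compound 1 this swap leaves the read-out where it was. The earlier step at this place, a 3.7-fold higher unbound fraction from compound 2 to compound 3 (0.56 log units; beyond the scatter), brought in a different group, 2-methoxyethyl, on a compound carrying trifluoromethyl, so replacing cyclopropyl here does not always free more compound. Nothing available explains why the two steps differ. The compounds shown leave open whether the contrast follows the entering group or the trifluoromethyl group elsewhere in the molecule, which ethoxy paired with trifluoromethyl, or 2-methoxyethyl on the core of compound 1, could help separate. They also leave open how an amine or a longer chain such as propoxy would behave on this carbon.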